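Quinoline chalcones: replacing the aminophenyl ketone with a thiophene

The compounds below may be only part of what the source reports. "The series", "measured", "known", "first", "only" and "open" are said of these compounds alone.

Measured compounds:
compound 1 `COc1ccc(C(=O)/C=C/c2nc3ccccc3cc2-c2ccc(OC)cc2)cc1` gives 6420 nM in a functional assay on NCI-H1299 cells (Homo sapiens) for antiproliferative activity, read by XTT assay, with a stated time of 72 h; a higher number here means a weaker inhibitor, a lower number a stronger inhibitor
compound 2 `COc1ccc(-c2cc3ccccc3nc2/C=C/C(=O)c2ccc(N)cc2)cc1` gives 6510 nM in this assay

Compound 2 holds the highest of the two numbers in this assay, yet its nearest neighbour is compound 1, and the step of a 1.0-fold higher number from compound 1 to compound 2 (0.01 log units; within the scatter) lies within the scatter, so the two compounds cannot be ordered. Compound 3 `COc1ccc(-c2cc3ccccc3nc2/C=C/C(=O)c2cccs2)cc1` has not yet been measured. It differs from compound 2 by thiophen-2-yl in place of 4-aminophenyl on a carbonyl carbon. Among the measured compounds shown here, the only measured step swaps one substituent on that aryl ring for another and left the number unchanged within the scatter, so it bears on the new change only loosely: the ring itself is now replaced rather than decorated. Nothing in the data points to a shift in either direction, so compound 3 is expected to stay near compound 2, giving an estimated step of a 1.1-fold higher number from compound 2 to compound 3 (0.03 log units; within the scatter). The estimate for compound 3 in this assay is 7000 nM, within a range from 2500 nM to 20000 nM.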

Compound 3, half-maximal inhibitory concentration: 720 nM
The estimate for compound 3 lay 9.7-fold (0.99 log units) above the measured number; the whole stated range lies above it.
By their numbers in this assay, from the lowest: compound 3; then compounds 1 and 2 (each within the scatter of the next).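

Replacing 4-aminophenyl with thiophen-2-yl on the carbonyl carbon gives a 9.0-fold lower number from compound 2 to compound 3 (0.96 log units; beyond the scatter) in this assay, and replacing 4-methoxyphenyl there gives an 8.9-fold lower number from compound 1 to compound 3 (0.95 log units; beyond the scatter) in the same assay. The earlier exchange on the aryl ring, a 1.0-fold higher number from compound 1 to compound 2 (0.01 log units; within the scatter), did not separate the compounds, whereas replacing the ring itself shows that the number at this position can move beyond the scatter. Nothing available explains this shift.

The compounds shown leave open whether the shift is particular to thiophen-2-yl or would also appear with another ring on the carbonyl carbon, such as furan-2-yl, thiophen-3-yl, pyridin-2-yl or an unsubstituted phenyl. They also leave open whether a thiophene carrying a methyl group or a chlorine atom would keep the lower number.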